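Replacing methanesulfonamido with hydroxy in compound 1

The source may hold more compounds than are shown below. What is called first, only, known or untested is meant among the compounds shown, and "the series" means these compounds.

In a physicochemical assay for solubility, read by nephelometry, measured as kinetic solubility, at pH 2.0 (a higher number here means a more soluble compound, a lower number a less soluble compound), compound 1 (`CC(C)(C)c1cc(C(=O)Nc2nc(CNS(C)(=O)=O)cs2)n(Cc2ccccc2)n1`) gives 3.1 ug/mL as the lowest number shown. Compound 3 (`COc1ccc(C(=O)Nc2nc(CN)cs2)cc1`) gives 50 ug/mL and stands well beyond the scatter above compound 1. Compound 2 (`NCc1csc(NC(=O)c2ccc(Cl)cc2)n1`) gives > 100 ug/mL which is a limit of the assay and not a number. Within the data shown here, the one measured step is an at least 2.0-fold lower number from compound 2 to compound 3 (0.30 log units; that floor lies within the scatter) and it puts methoxy in place of chloro on an aromatic carbon. That is a different swap at a different place, and it sets no size for the change considered here.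

Compound 4 (`CC(C)(C)c1cc(C(=O)Nc2nc(CO)cs2)n(Cc2ccccc2)n1`) keeps the core of compound 1 and differs by hydroxy in place of methanesulfonamido on a saturated chain carbon bound to an aromatic carbon with hydroxy in place of methanesulfonamido on a saturated chain carbon bound to an aromatic carbon. Among the measured compounds shown here, no measured step covers this change, so the expectation rests only on compound 1 at 3.1 ug/mL in this assay as its anchor. What is expected is a 1.3-fold higher number from compound 1 to compound 4 (0.11 log units; within the scatter) and no step beyond the scatter. Compound 4 is expected at 4 ug/mL with an estimated range of 1.5 ug/mL to 12 ug/mL for this measurement.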

Compound 4, solubility: 12.5 ug/mL
Beside the measured number, compound 4's estimate is 3.1-fold (0.49 log units) below it; measured number outside the range, above it.
By their numbers in this assay, from the lowest: compound 1; then compound 4; then compound 3. At a limit, above all of these: compound 2.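

In this assay, among these compounds, the step of a 4.0-fold higher number from compound 1 to compound 4 (0.61 log units; beyond the scatter) is the only measured change at this position, where (methanesulfonamido)methyl gives way to hydroxymethyl on the shared core. The earlier compounds shown here offered only methoxy in place of chloro on an aromatic carbon, a different swap at a different place, and so set no size for a change on this saturated chain carbon bound to an aromatic carbon. This step now sets one for the core of compound 1, and it lies beyond the scatter, though nothing shown here gives a cause for it.

Only methanesulfonamido and hydroxy are shown at this place, so it remains open how a carboxylic acid or a longer chain ending in hydroxy would read there. As far as these compounds go, it also remains open whether the same swap would give a step of like size on any other core.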